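A few compounds are considered here, and "the series" means these few. Any claim that something is new, unique, unknown or untested is made for them only; others in the source may bear on it.

Measured in a functional assay on HeLa cells (Homo sapiens) for cytotoxicity, read by sulforhodamine B assay; on this read-out lower numbers stand for stronger inhibition and higher numbers for weaker inhibition:
- compound 1 `Cc1ccc(S(=O)(=O)NC(C2=CC(=O)c3c(O)ccc(O)c3C2=O)C(C)C)cc1`: 4850 nM
- compound 2 `CC(C)C(NS(=O)(=O)c1ccc(Cl)cc1)C1=CC(=O)c2c(O)ccc(O)c2C1=O`: 8650 nM
- compound 3 `CCOC(=O)c1ccc(S(=O)(=O)NC(C2=CC(=O)c3c(O)ccc(O)c3C2=O)C(C)C)cc1`: 850 nM

Compound 1 lies within the scatter of compound 2, and only compound 3 is clearly lower. Next is compound 4 `Cc1ccc(S(=O)(=O)NC(C)C2=CC(=O)c3c(O)ccc(O)c3C2=O)cc1`: methyl in place of isopropyl on a saturated chain carbon bound to a double-bonded ring carbon and a sulfonamide nitrogen. Going by the values given here, no measured step touches this carbon. The steps of a 1.8-fold higher number from compound 1 to compound 2 (0.25 log units; within the scatter), a 5.7-fold lower number from compound 1 to compound 3 (0.76 log units; beyond the scatter) and a 10-fold lower number from compound 2 to compound 3 (1.01 log units; beyond the scatter) all change a group on an aromatic carbon, so they show only how far the series can move. No shift beyond the scatter is therefore expected in this assay, and the expected step is a 1.0-fold lower number from compound 1 to compound 4 (0.00 log units; within the scatter). The estimate for compound 4 is 4800 nM, with an expected range of 1600 nM to 14000 nM.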

Compound 4, half-maximal inhibitory concentration: 5340 nM
Compound 4: middle estimate off by 1.1-fold (0.05 log units), on the low side, and the stated range covers the measured number.
By their numbers in this assay, from the lowest: compound 3; then compounds 1, 4 and 2 (each within the scatter of the next).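

In this assay, methyl in place of isopropyl on a saturated chain carbon bound to a double-bonded ring carbon and a sulfonamide nitrogen gives a 1.1-fold higher number from compound 1 to compound 4 (0.04 log units; within the scatter). This first step at this carbon shows that, with the aromatic methyl of compound 1 kept, going from 3 heavy atoms to 1 leaves the number within the scatter. No measurement here bears on why this is so.

Going by these compounds, whether the same holds alongside the ethoxycarbonyl group of compound 3 remains open. So does the effect of a longer chain, a phenyl ring or an amine at this carbon.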